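Ester to Hydroxymethyl: Compound 1 to Compound 4

A few compounds are considered here, and "the series" means these few. Any claim that something is new, unique, unknown or untested is made for them only; others in the source may bear on it.

The compounds are compared in a physicochemical assay for lipophilicity, at pH 7.4; a higher number here means a more lipophilic compound, a lower number a more polar compound. Compound 1 `COC(=O)c1cc(N)c(Nc2ccc(C#N)cc2)cc1Oc1c(C)cc(/C=C/C#N)cc1C` gives 4.15. Compound 3 `Cc1cc(CCC#N)cc(C)c1Oc1cc(Nc2ccc(C#N)cc2)c(N)cc1C(N)=O` gives 2.65. Compound 2 `Cc1cc(CCC#N)cc(C)c1Oc1cc(Nc2ccc(C#N)cc2)c(N)cc1C(F)(F)F` reaches only a limit of the assay, > 5, and so supplies no number (the limit of > 5 in this assay, at which 1 of the 3 values shown sits). Of the two numbers, compound 1 stands highest; compound 3 is the nearest, clearly lower and beyond the scatter.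

Among the compounds with values here, only one measured step is available, and it concerns a group on an aromatic carbon of the shared core: a number at least 2.35 log units lower from compound 2 to compound 3 (beyond the scatter). Compound 4 `Cc1cc(/C=C/C#N)cc(C)c1Oc1cc(Nc2ccc(C#N)cc2)c(N)cc1CO` is yet to be measured; it differs from compound 1 as follows: hydroxymethyl in place of methoxycarbonyl on an aromatic carbon.

The measured step does not exchange the same pair of groups, so it bears on this change only loosely; it shows that exchanging one substituent for another on the core can move the reading by a large amount, and that carbamoyl brought the reading far down. For hydroxymethyl in place of methoxycarbonyl a smaller drop is expected, lowering the reading but less than in the measured step, an estimated a number 1.05 log units lower from compound 1 to compound 4 (beyond the scatter). Compound 4 is therefore estimated at 3.1, expected to fall between 2.5 and 3.7.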

Compound 4, partition coefficient: 4.14
Compound 4: middle estimate off by 1.04 log units, on the low side, outside the stated range (above it).
By their numbers in this assay, from the lowest: compound 3; then compounds 4 and 1 (each within the scatter of the next). At a limit, above all of these: compound 2.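

In this assay, hydroxymethyl in place of methoxycarbonyl on this aromatic carbon, ortho to a large group and para to a (4-cyanophenyl)amino group, gives a number 0.01 log units lower from compound 1 to compound 4 (within the scatter), so this read-out does not separate the two groups on the core of compound 1. The large step seen with carbamoyl in place of trifluoromethyl at the same carbon therefore does not carry over to this pair of groups, even though the two groups here differ in heavy atoms and in hydrogen-bond donors and acceptors, and a change of substituent at this carbon need not shift the reading. Nothing at hand accounts for this result.

Still open, going by these compounds, is how other groups at this carbon would read: a carboxylic acid, an aminomethyl group or a longer chain such as hydroxyethyl would show whether the reading stays level with compound 1 or moves as far as it did with carbamoyl. Also open, on these data alone, is whether hydroxymethyl and methoxycarbonyl read alike when the shared core carries the chain of compound 3 instead of that of compound 1.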